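Taking the pyrazole off compound 2: an expected loss

A few compounds are considered here, and "the series" means these few. Any claim that something is new, unique, unknown or untested is made for them only; others in the source may bear on it.

Of the compounds shown here, three that share one core have so far been tested in an assay on isolated protein for inhibition of Leucine-rich repeat serine/threonine-protein kinase 2 variant G2019S (Homo sapiens), read by TR-FRET and LanthaScreen, with stated times of 50 min and 30 min, in the presence of a further agent that is not named here; on this read-out lower numbers stand for stronger inhibition and higher numbers for weaker inhibition. Compound 1, `Cn1c(N2CCCC2)c(C#N)c2c(N)ncnc21`, gives 1910 nM. Compound 2, `C[C@@H]1CCCN1c1c(C#N)c2c(N)nc(Nc3cn(C)nc3C(F)(F)F)nc2n1C`, gives 358 nM. Compound 3, `C[C@@H]1CCCN1c1c(C(N)=O)c2c(N)ncnc2n1C`, gives 2240 nM. Compound 2 has the lowest number of the three, and both other compounds stand beyond the usual scatter above it, so compound 2 is the strongest inhibitor in this small set.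

Compound 4, `C[C@@H]1CCCN1c1c(C#N)c2c(N)nc(N)nc2n1C`, has not yet been measured. It differs from compound 2 in one place: hydrogen in place of 1-methyl-3-(trifluoromethyl)-1H-pyrazol-4-yl on a nitrogen on an aromatic ring. The 1-methyl-3-(trifluoromethyl)-1H-pyrazol-4-yl leaves, and hydrogen enters on a nitrogen on an aromatic ring.

Going by the values given here, no pair of measured compounds shows this exact change on its own. Still, compound 1 and compound 3, which both lack the 1-methyl-3-(trifluoromethyl)-1H-pyrazol-4-yl, sit at high numbers, while compound 2, which carries it, gives 358 nM. The step from compound 2 to compound 4 is therefore expected to be a 4.2-fold higher number from compound 2 to compound 4 (0.62 log units; beyond the scatter), upward toward weaker inhibition and beyond the scatter. Compound 4 is estimated at 1500 nM, with a likely range from 500 nM to 5000 nM.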

Compound 4, half-maximal inhibitory concentration: 217 nM
Estimate against measurement, compound 4: 6.9-fold (0.84 log units) above, and the stated range ends above it.
By their numbers in this assay, from the lowest: compounds 4 and 2 (each within the scatter of the next); then compounds 1 and 3 (each within the scatter of the next).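

In this assay, replacing the 1-methyl-3-(trifluoromethyl)-1H-pyrazol-4-yl on this nitrogen with hydrogen gives a 1.6-fold lower number from compound 2 to compound 4 (0.22 log units; within the scatter), so the two compounds cannot be told apart, even though a whole ring system with 10 heavy atoms has gone. The number of compound 2 therefore cannot be credited to this group, and the higher numbers of compound 1 and compound 3 say nothing about it, as each differs from compound 2 in more than one place. Nothing available here explains why so large a change leaves the number within the scatter.

Still open, going by these compounds, is whether a methyl or an acetyl on this nitrogen would give a number beyond the scatter of compound 4, and whether a phenyl ring or a 1-methylpyrazol-4-yl without the trifluoromethyl would match compound 2. Also open, on these data alone, is whether the same exchange would again stay within the scatter on a compound that carries the carboxamide of compound 3 in place of the nitrile.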